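The source may report more compounds than this note shows. Statements on the series, on what has been measured and on what is new or still open speak of the compounds shown alone.

Values in a functional assay on HCT-116 cells (Homo sapiens) for antiproliferative activity, read by MTT assay, with a stated time of 72 h (a higher number here means a weaker inhibitor, a lower number a stronger inhibitor), for the measured members of the series:
Compound 1 `Cn1cc(-c2nn(Cc3ccc(C(=O)N4CCCCC4)cc3)c(=O)c3ccccc23)cn1`: 73900 nM
Compound 2 `CN1CCC(NC(=O)c2ccc(Cn3nc(-c4cnn(C)c4)c4ccccc4c3=O)cc2)CC1`: 69500 nM
Compound 3 `Cc1noc(C)c1-c1nn(Cc2ccc(C(=O)NC3CC3)cc2)c(=O)c2ccccc12`: > 100000 nM, which is a limit of the assay and not a number.

Compound 3 stands at the limit, (the limit of > 100000 nM in this assay, at which 1 of the 3 values shown sits). Compound 1 and compound 2 each return a number in this assay, so compound 3 sits no better than either of them on the numbers shown, and how far it lies beyond them is unknown.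

Compound 4 `Cc1noc(C)c1-c1nn(Cc2ccc(C(=O)N3CCCCC3)cc2)c(=O)c2ccccc12` differs from compound 3 in one place: piperidin-1-yl in place of cyclopropylamino on a carbonyl carbon. Within the data shown here, the only measured step at the same carbonyl carbon is a 1.1-fold lower number from compound 1 to compound 2 (0.03 log units; within the scatter), an exchange of piperidin-1-yl for an amino-linked piperidine that stays within the scatter. Among the measured compounds shown here, that step runs on a different core substituent than the one shared by compound 3 and compound 4, so it bears on the present change only by analogy. On that analogy, the amide variation is expected to move the number little, and the expected step is a number no higher from compound 3 to compound 4 (the limit leaves the size open). Compound 4 is therefore estimated at 100000 nM, with a range from 45000 nM to 250000 nM, and a limit reading remains likely.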

Compound 4, half-maximal inhibitory concentration: > 100000 nM
Compound 4 was reported as a limit; the forecaster's own chance of this, stated with the estimate: 55%; the middle value lies on the limit itself.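

In this assay the exchange of cyclopropylamino for piperidin-1-yl on the carbonyl carbon cannot be read, as compound 3 and compound 4 both end at a limit of the assay: the limit of > 100000 nM in this assay, at which 2 of the 4 values shown sit. With piperidin-1-yl held constant, the exchange of 1-methyl-1H-pyrazol-4-yl for 3,5-dimethyl-1,2-oxazol-4-yl on an aromatic carbon gives an at least 1.3-fold higher number from compound 1 to compound 4 (0.13 log units; that floor lies within the scatter), so the step is only a floor and no change beyond the scatter is shown. The piperidin-1-yl amide that returns a number in compound 1 returns only a limit in compound 4.

On these data alone, how far compound 3 and compound 4 lie beyond the limit remains open, and with it any effect of the amide on this core. Also open, as far as these compounds go, is how this assay would read with a carboxylic acid on the benzene-linked carbonyl carbon, or with pyridin-3-yl on the aromatic carbon.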